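Ether chain variation in a cytotoxicity series

A few compounds are considered here, and "the series" means these few. Any claim that something is new, unique, unknown or untested is made for them only; others in the source may bear on it.

Compound 1 `CC(C)COc1ccc2c(Cl)ccnc2c1`: in a functional assay on BGC-823 cells (Homo sapiens) for cytotoxicity, read by MTT assay, with a stated time of 48 h (on this read-out lower numbers stand for stronger inhibition and higher numbers for weaker inhibition), compound 1 gives 3030 nM.
Compound 2 `CCOc1ccc2c(Cl)ccnc2c1`: in this assay compound 2 gives 3910 nM.

Going by the values given here, compound 2 holds the highest of the two numbers measured so far in this assay; its nearest neighbour is compound 1, and the step of a 1.3-fold higher number from compound 1 to compound 2 (0.11 log units; within the scatter) lies within the scatter, so no order between the two is claimed. Compound 3 `C=CCOc1ccc2c(Cl)ccnc2c1` differs from compound 2 by vinyl in place of methyl on a saturated chain carbon bound to an oxygen on an aromatic ring. Among the compounds with values here, the only measured step that bears on this change is a 1.3-fold higher number from compound 1 to compound 2 (0.11 log units; within the scatter), an exchange of groups at the same place on the chain that stayed within the scatter. On that basis no step beyond the scatter is expected in this assay, and the expected step is a 1.1-fold lower number from compound 2 to compound 3 (0.05 log units; within the scatter). Compound 3 is therefore estimated to give about 3500 nM in this assay, within a range from 1800 nM to 7000 nM.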

Compound 3, half-maximal inhibitory concentration: 2930 nM
Compound 3: middle estimate off by 1.2-fold (0.08 log units), on the high side; low and high end bracket the measured number.
By their numbers in this assay, from the lowest: compounds 3, 1 and 2 (each within the scatter of the next).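

In this assay, ethoxy to allyloxy gives a 1.3-fold lower number from compound 2 to compound 3 (0.13 log units; within the scatter), so the first chain with a double bond outside the aromatic rings remains within the scatter of the saturated ethoxy chain of compound 2. Vinyl in place of isopropyl gives a 1.0-fold lower number from compound 1 to compound 3 (0.01 log units; within the scatter), so these two different chain ends also cannot be told apart, and all three ethers at this place form a single group with no order among them. No measurement is available that would explain this lack of separation.

As far as these compounds go, whether an amine, a carboxylic acid or a much longer chain at this place would give a step beyond the scatter remains open. Also open is whether the same lack of separation among these three ether chains would hold on a core other than the one they share.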